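Turning One Double Bond from E to Z

A few compounds are considered here, and "the series" means these few. Any claim that something is new, unique, unknown or untested is made for them only; others in the source may bear on it.

Compound 1 `Cc1ccc(/C=C\c2ccc3ccccc3c2)cc1` gives > 5000 nM, a limit
Compound 2 `FC(F)(F)c1ccc(/C=C/c2ccc3ccccc3c2)cc1` gives > 5000 nM, a limit

In a functional assay on P388 cells (Mus musculus) for inhibition (a higher number here means a weaker inhibitor, a lower number a stronger inhibitor), compound 2 gives no exact number, only the limit > 5000 nM. Compound 1 also reaches only a limit, > 5000 nM. The picture so far is therefore (the limit of > 5000 nM in this assay, at which 2 of the 2 values shown sit).

Compound 3 `FC(F)(F)c1ccc(/C=C\c2ccc3ccccc3c2)cc1` alters only the configuration as drawn: the two compounds have the same atoms and bonds and differ only in configuration as drawn: 1 of 1 stereo elements differ; a double bond is drawn E in compound 2 and Z in compound 3. Among the compounds with values here, no measured step yet shows what such a change does in this assay. Compound 1 is also drawn Z, and its > 5000 nM is a limit, so a Z double bond has not yet come with a measurable number here. The expected change is none beyond the scatter, an estimated step that the limit leaves unreadable from compound 2 to compound 3. Another limit is the likeliest outcome. For compound 3 the estimated value is 7000 nM, with an expected range of 2500 nM to 20000 nM.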

Compound 3, half-maximal inhibitory concentration: > 5000 nM
Compound 3 gave a limit, no number; the forecaster's own chance of this, stated with the estimate: 75%; the middle value is on the limit's open side.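

In this assay compound 3 gives > 5000 nM, again a limit. Neither its step from compound 1 nor its step from compound 2 can be read: the limit of > 5000 nM in this assay, at which 3 of the 3 values shown sit.

Still open, going by these compounds, is whether the E or Z drawing of the double bond, or trifluoromethyl in place of methyl, alters inhibition at all.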